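This account rests on a few compounds, and the source may have more. Where it says the series, first, only, none or still open, it means among the compounds named here.

Measured so far in an ADME assay for protein binding, using equilibrium dialysis, at pH 7.4, tested at 2 uM; a lower number here means a smaller unbound share, a higher number a larger unbound share of the compound:

- compound 1 `CC(C)N(c1cc(C#CC(C)(C)C)sc1C(=O)O)C(=O)[C@H]1CC[C@H](C)CC1` gives 0.06
- compound 2 `CC(C)N(C(=O)C1CCC(F)(F)CC1)c1cc(C#CC(C)(C)C)sc1C(=O)O` gives 0.4
- compound 3 `CC(C)N(C(=O)[C@H]1[C@@H]2CCCC[C@@H]21)c1cc(C#CC(C)(C)C)sc1C(=O)O` gives 0.04

Compound 1 sits level with compound 3, the gap being a 1.5-fold lower number from compound 1 to compound 3 (0.18 log units; within the scatter), and well apart from compound 2, the gap being a 6.7-fold higher number from compound 1 to compound 2 (0.82 log units; beyond the scatter). The widest gap of the three is a 10-fold lower number from compound 2 to compound 3 (1.00 log units; beyond the scatter). Compound 2 stands apart from the other two in this assay.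

Compound 4 `CC(C)(C)C#Cc1cc(N(C(=O)[C@H]2CC[C@H](C)CC2)[C@H]2CC[C@H](O)CC2)c(C(=O)O)s1` keeps the 4-methylcyclohexyl on the carbonyl carbon of compound 1 and changes the other side of the amide: 4-hydroxycyclohexyl in place of isopropyl on an amide-type nitrogen. Among the measured compounds shown here, no measured step touches this nitrogen substituent. All three swap the group on the carbonyl carbon, so they offer only an indirect guide to how far one swap can move the number. Compound 2 shows upward movement, with a 6.7-fold higher number from compound 1 to compound 2 (0.82 log units; beyond the scatter) as its step, while compound 3 shows a swap that moves nothing beyond the scatter, with a 1.5-fold lower number from compound 1 to compound 3 (0.18 log units; within the scatter) as its step. For the measured compounds named here, a modest rise, smaller than the one to compound 2, is therefore expected, with little confidence in its direction. The expected change is a 2.2-fold higher number from compound 1 to compound 4 (0.34 log units; beyond the scatter) in this estimate. Compound 4 is estimated at 0.13 in this assay, with an expected range from 0.05 to 0.3 here.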

Compound 4, unbound fraction: 0.19
For compound 4 the middle estimate is 1.5-fold (0.16 log units) below the measured one, within the range that was stated.
By their numbers in this assay, from the lowest: compounds 3 and 1 (each within the scatter of the next); then compound 4; then compound 2.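

In this assay, among the compounds shown here, the step at the amide-type nitrogen is the first in this set that leaves the group on the carbonyl carbon untouched: 4-hydroxycyclohexyl in place of isopropyl gives a 3.2-fold higher number from compound 1 to compound 4 (0.50 log units; beyond the scatter). This shows that the nitrogen substituent, and not only the group on the carbonyl carbon, can move the unbound fraction beyond the scatter, here upward from the level shared by compound 1 and compound 3. The change brings in a six-membered ring, more heavy atoms, and a hydrogen-bond donor and acceptor all at once, and nothing available here ties the rise to any one of these features or accounts for it.

On these data alone, it remains open whether a plain cyclohexyl or a 4-aminocyclohexyl on this nitrogen would give a similar step, which would help separate the part played by the ring from that of the hydroxyl group. As far as these compounds go, it is also open whether 4-hydroxycyclohexyl on the nitrogen would raise the number to the same extent with the 4,4-difluorocyclohexyl of compound 2 on the carbonyl carbon.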